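Series notes: dichlorophenyl swap on the nitrooxy analogue

The compounds below may be only part of what the source reports. "The series", "measured", "known", "first", "only" and "open" are said of these compounds alone.

Measured so far:
compound 1 `COc1ccc(C2=NN(C(=O)CBr)C(c3c(Cl)cccc3Cl)C2)cc1OC`, 69%
compound 2 `COc1ccc(C2=NN(C(=O)CO[N+](=O)[O-])C(c3ccco3)C2)cc1OC`, 43%

In a functional assay on the whole organism (strain albino) for inhibition, with Rattus norvegicus as the target, read by paw edema, with stated times of 30 min and 3 h, at a dose of 100 mg/kg by the oral route (on this read-out higher numbers stand for more inhibition at the one dose given (going by the name of the read-out) and lower numbers for less inhibition), compound 1 gives 69% and compound 2 gives 43%. Compound 2 stands lowest of the two numbers; its nearest neighbour, compound 1, lies higher by a gap beyond the scatter. Among the measured compounds shown here, these two differ in more than one place, so no single step is read from them.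

Compound 3 `COc1ccc(C2=NN(C(=O)CO[N+](=O)[O-])C(c3c(Cl)cccc3Cl)C2)cc1OC` is the next candidate in this assay. 2,6-dichlorophenyl in place of furan-2-yl on a saturated ring carbon Compound 3 thus combines the 2,6-dichlorophenyl of compound 1 with the ((nitrooxy)methyl)carbonyl group of compound 2. An upward step of moderate size is expected, a number 13 percentage points higher from compound 2 to compound 3 (beyond the scatter). This rests on compound 1 giving 69% with the same aryl group. Compound 3 is estimated at 56%, range 42% to 70%.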

Compound 3, a percentage reported as inhibition, in the whole organism at one dose (the size of the read-out at that dose, not a potency): 58%
Compound 3: the middle estimate sits 2 percentage points below what was measured; measured number inside the range.
By their numbers in this assay, from the lowest: compound 2; then compound 3; then compound 1.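

With the nitrooxy group held fixed, 2,6-dichlorophenyl in place of furan-2-yl on the saturated ring carbon gives a number 15 percentage points higher from compound 2 to compound 3 (beyond the scatter) in this assay and so shows that this position affects the read-out. With 2,6-dichlorophenyl held fixed, nitrooxy in place of bromo on the chain carbon bound to the carbonyl carbon gives a number 11 percentage points lower from compound 1 to compound 3 (beyond the scatter) as a separate single change. No evidence on the origin of either step is at hand.

Open, as far as these compounds go, is how an unsubstituted phenyl would read on that ring carbon. Also open, from the compounds shown here alone, is how a dimethylamino group would read in place of bromo or nitrooxy on the chain.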